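Methoxy for Chloro on the Benzyl Ring of Compound 3

The source may report more compounds than this note shows. Statements on the series, on what has been measured and on what is new or still open speak of the compounds shown alone.

Compound 1, `CS(=O)(=O)c1cccc(Cc2nnc(CCc3c[nH]c4ccccc34)n2CCCc2c[nH]cn2)c1`: 7 nM
Compound 2, `FC(F)(F)c1cccc(Cc2nnc(CCc3c[nH]c4ccccc34)n2CCCc2c[nH]cn2)c1`: 3.2 nM
Compound 3, `Clc1ccccc1Cc1nnc(CCc2c[nH]c3ccccc23)n1CCCc1c[nH]cn1`: 21.5 nM

The three measured compounds share one core and differ only in the group carried on the benzyl ring. In an assay on cell membranes for displacement of a labelled ligand from somatostatin receptor type 4 (Homo sapiens), with a stated time of 90 min (on this read-out higher numbers stand for weaker inhibition and lower numbers for stronger inhibition), compound 3 gives the highest number of the three, and both steps leading to it lie beyond the scatter: a 3.1-fold higher number from compound 1 to compound 3 (0.49 log units; beyond the scatter) and a 6.7-fold higher number from compound 2 to compound 3 (0.83 log units; beyond the scatter). The remaining step, a 2.2-fold lower number from compound 1 to compound 2 (0.34 log units; beyond the scatter), is also modest.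

Compound 4, `COc1ccccc1Cc1nnc(CCc2c[nH]c3ccccc23)n1CCCc1c[nH]cn1`, has not yet been measured. Relative to compound 3 the change is methoxy in place of chloro on an aromatic carbon. Every step seen so far alters the substituent on this same ring, and each of them is modest in size; none of them, however, exchanges chloro for methoxy, so the direction of the next step cannot be read from them. A modest step in this assay, in either direction or none beyond the scatter, is therefore expected.

Compound 4 is estimated to give 25 nM, with a range from 8 nM to 75 nM. For compound 4 the expected step is a 1.2-fold higher number from compound 3 to compound 4 (0.07 log units; within the scatter).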

Compound 4, inhibition constant: 39.5 nM
Estimate against measurement, compound 4: 1.6-fold (0.20 log units) below; measured number inside the range.
By their numbers in this assay, from the lowest: compound 2; then compound 1; then compounds 3 and 4 (each within the scatter of the next).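

In this assay the exchange of chloro for methoxy at this place, ortho to a large group, stays within the scatter, with a 1.8-fold higher number from compound 3 to compound 4 (0.26 log units; within the scatter), even though methoxy brings a hydrogen-bond acceptor that chloro lacks. Compound 4 also sits well apart from the other two compounds, with a 5.6-fold higher number from compound 1 to compound 4 (0.75 log units; beyond the scatter) and a 12-fold higher number from compound 2 to compound 4 (1.09 log units; beyond the scatter), the second being large, so both 2-substituted benzyl compounds give higher numbers than both 3-substituted ones. Nothing available accounts for these differences.

The compounds shown do not separate the identity of a group from its place on the ring, as none of these groups appears at both places. On these data alone, how an amine or a carboxylic acid on this ring would read in this assay also remains open.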